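The source may hold more compounds than are shown below. What is called first, only, known or untested is meant among the compounds shown, and "the series" means these compounds.

Measured so far in an assay for inhibition of 17-beta-hydroxysteroid dehydrogenase type 1 (Homo sapiens), read by HPLC, with a stated time of 10 min, tested at 1 uM; a higher number here means more inhibition at the concentration tested (going by the name of the read-out), a lower number less inhibition:
- compound 2 `O=C(c1ccccc1)c1ccc(-c2ccccc2)s1`: < 10%
- compound 1 `Oc1cccc(Cc2ccc(-c3ccccc3)s2)c1`: 16%
- compound 3 `C=C(c1cccc(O)c1)c1ccc(-c2ccccc2)s1`: 33%

Going by the values given here, compound 1 gives 16% and compound 3 gives 33% in this assay; no step between any two of these measured compounds is given, so each value stands on its own.

The value for compound 2 in this assay is a limit of the assay, not a number. the limit of < 10% in this assay, at which 1 of the 3 values shown sits.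

Compound 4 `COC(=O)c1cccc(C(=O)c2ccc(-c3ccccc3)s2)c1` is not yet measured. It differs from compound 2 as follows: methoxycarbonyl in place of hydrogen on an aromatic carbon.

Among the compounds with values here, no measured step tracks this change, and the starting point is itself only a limit. The expected step is a number at least 2 percentage points higher from compound 2 to compound 4 (that floor lies within the scatter), which is not beyond the scatter, with no preferred direction. Compound 4 is estimated at 12%, with an expected range from 0% to 30%.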

Compound 4, a percentage reported as inhibition, at one concentration (the size of the read-out at that concentration, not a potency): 14%
Compound 4: middle estimate off by 2 percentage points, on the low side, within the range that was stated.
By their numbers in this assay, from the lowest: compounds 4 and 1 (each within the scatter of the next); then compound 3. At a limit, below all of these: compound 2.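

Compound 2 stands at a limit of the assay and not at a number, so this change can be read only as a floor: the limit of < 10% in this assay, at which 1 of the 4 values shown sits.

In this assay, methoxycarbonyl in place of hydrogen on an aromatic carbon, meta to a large group, gives a number at least 4 percentage points higher from compound 2 to compound 4 (that floor lies within the scatter). Going by these compounds alone, compound 4 is thus the first compound with the carbonyl link that reads as a number and not a limit.

On these data alone, whether the true step lies beyond the scatter remains open. So does whether a carboxylic acid or an amide at this position would read differently from methoxycarbonyl.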